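The source may report more compounds than this note shows. Statements on the series, on what has been measured and on what is new or still open speak of the compounds shown alone.

Measured so far in an assay on HEK293 cells for displacement of a labelled ligand from Melanocortin receptor 4 (Homo sapiens); a lower number here means a stronger inhibitor, a higher number a weaker inhibitor:
- compound 1 `CCC(C)[C@H](N)c1cc(C(F)(F)F)ccc1N1CCN(C(=O)CCc2ccc(Cl)cc2)CC1` — 86 nM
- compound 2 `CC(C)C[C@H](N)c1cc(C(F)(F)F)ccc1N1CCN(C(=O)CCc2c(Cl)cccc2Cl)CC1` — 2600 nM
- compound 3 `CCC(C)CN[C@H](c1cc(C(F)(F)F)ccc1N1CCN(C(=O)CCc2ccc(Cl)cc2Cl)CC1)C(C)CC` — 2800 nM

Compound 3 carries the highest number of the three. Compound 2 stands nearest to it, and the gap between them lies within the usual scatter, so the two cannot be told apart on these numbers. Compound 1 stands furthest away with a far lower number, a gap well beyond the scatter. Going by the values given here, no two of the measured compounds differ in one place only, so no single measured step is available for comparison.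

Compound 4 `CCC(C)[C@H](NC(C)=O)c1cc(C(F)(F)F)ccc1N1CCN(C(=O)CCc2ccc(Cl)cc2Cl)CC1` is the untested member. Relative to compound 3 the change is acetyl in place of 2-methylbutyl on an amine nitrogen. Among the compounds with values here, nothing among the measured compounds isolates a change of this kind, and compound 1, the only one with an unsubstituted amine, also differs from compound 3 elsewhere, so it gives no clean read on the amine nitrogen. In this assay compound 4 is therefore expected to stay close to compound 3, with an expected step of a 1.1-fold higher number from compound 3 to compound 4 (0.03 log units; within the scatter) that does not clearly exceed the scatter in either direction. The estimate for compound 4 is 3000 nM, with a wide range from 600 nM to 15000 nM.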

Compound 4, inhibition constant: 360 nM
Beside the measured number, compound 4's estimate is 8.3-fold (0.92 log units) above it; the whole stated range lies above it.
By their numbers in this assay, from the lowest: compound 1; then compound 4; then compounds 2 and 3 (each within the scatter of the next).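

In this assay, going by these compounds alone, the exchange of 2-methylbutyl for acetyl on the amine nitrogen gives a 7.8-fold lower number from compound 3 to compound 4 (0.89 log units; beyond the scatter), the only step that changes one place alone. Within the data shown here, the group on this nitrogen therefore moves the number beyond the scatter with the rest of the structure held fixed, and an earlier comparison could not show this because compound 1, the only measured compound with an unsubstituted amine, also differs elsewhere. No measurement at hand bears on why the step has this direction or size.

As far as these compounds go, the step removes one group and adds another in a single move, so it remains open whether the lower number follows from the loss of 2-methylbutyl or the arrival of acetyl, and the unsubstituted amine on the core of compound 4 would separate the two. Also open are how a methyl group, a longer acyl chain such as propanoyl, or a methanesulfonyl group on this nitrogen would compare, and whether the step holds on the other cores shown.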